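The source may hold more compounds than are shown below. What is called first, only, known or untested is meant among the compounds shown, and "the series" means these compounds.

Of the compounds shown here, three built on the same core have been measured in an assay for inhibition of beta-N-acetyl-D-hexosaminidase-A/B (Homo sapiens); a higher number here means a weaker inhibitor, a lower number a stronger inhibitor. Compound 1 `CCc1nc(N)nc(N)c1-c1cccc(C)c1` gives 34000 nM, and compound 2 `CCc1nc(N)nc(N)c1-c1ccc(C)cc1` gives 40000 nM, the larger of the two numbers, though the two lie within the scatter of each other. Compound 3 `CC(C)c1nc(N)nc(N)c1-c1ccc(Cl)cc1` reaches only the limit of this assay, > 410000 nM, so for it no number is known; this is the limit of > 410000 nM in this assay, at which 1 of the 3 values shown sits.

Compound 4 `CCc1nc(N)nc(N)c1-c1ccc(C(F)(F)F)cc1` has not yet been measured in this assay. It differs from compound 2 by trifluoromethyl in place of methyl on an aromatic carbon. For the measured compounds named here, no step between measured compounds that differ only at this position exists, so the direction has to be judged from what is available. Compound 3, which carries a different group at this place, gave only a limit, which makes a move toward weaker inhibition seem at least as likely as a move toward stronger. Compound 4 is therefore expected to show a modest weakening, a 1.8-fold higher number from compound 2 to compound 4 (0.24 log units; within the scatter), with a real chance that only a limit is reported. The estimate for compound 4 in this assay is 70000 nM, within a range from 20000 nM to 250000 nM.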

Compound 4, half-maximal inhibitory concentration: 15000 nM
For compound 4 the middle estimate is 4.7-fold (0.67 log units) above the measured one; the whole stated range lies above it.
By their numbers in this assay, from the lowest: compound 4; then compounds 1 and 2 (each within the scatter of the next). At a limit, above all of these: compound 3.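

For the compounds shown here, the change gives the first readable step at this position, on an aromatic carbon para to a large group: trifluoromethyl in place of methyl gives a 2.7-fold lower number from compound 2 to compound 4 (0.43 log units; beyond the scatter). This shows that in this assay inhibition responds to the group at this place, and that a group of four heavy atoms in place of one goes here with stronger inhibition, not weaker. Compound 3 differs from compound 4 in more than one place and cannot be read against this step, and nothing shown gives a reason for the step.

Whether the step belongs to trifluoromethyl alone stays open, since a methoxy group, a nitrile or a carboxylic acid at this place is not among the compounds shown. Also open, going by these compounds, is how a longer chain in place of the ethyl group would act alongside trifluoromethyl.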